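From 4-fluorophenyl to 2-bromophenyl in compound 4

A few compounds are considered here, and "the series" means these few. Any claim that something is new, unique, unknown or untested is made for them only; others in the source may bear on it.

In a functional assay for inhibition, with Homo sapiens as the target (on this read-out lower numbers stand for tighter binding and higher numbers for weaker binding), compound 1 `O=C(O)CC/C=C\CC1COC(c2cccs2)OC1c1cccnc1` gives 1000 nM, compound 2 `O=C(O)CC/C=C\CC1COC(c2ccco2)OC1c1cccnc1` gives 1260 nM, and compound 3 `CC(C)(Oc1ccc(F)cc1)C1OCC(C/C=C\CCC(=O)O)C(c2cccnc2)O1` gives 120 nM. Compound 3 therefore holds the lowest of these three numbers, clearly apart from the other two.

Compound 4 `CC(C)(Oc1ccccc1Br)C1OCC(C/C=C\CCC(=O)O)C(c2cccnc2)O1` has not yet been measured. It differs from compound 3 in one place: 2-bromophenyl in place of 4-fluorophenyl on an oxygen on a saturated carbon. In words, 2-bromophenyl stands in place of 4-fluorophenyl on an oxygen on a saturated carbon, so 4-fluorophenoxy becomes 2-bromophenoxy.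

Among the measured compounds shown here, only one measured step links two compounds differing in one place: a 1.3-fold higher number from compound 1 to compound 2 (0.10 log units; within the scatter). That step is a different swap, furan-2-yl in place of thiophen-2-yl on a saturated ring carbon, so it offers only a weak guide. For the measured compounds named here, no measured pair changes the group on the oxygen. With so little evidence, no shift beyond the scatter is expected, although the uncertainty is wide. The estimated step is a 1.2-fold lower number from compound 3 to compound 4 (0.08 log units; within the scatter). In this assay, compound 4 is expected to give about 100 nM, within an estimated range of 25 nM to 400 nM.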

Compound 4, dissociation constant: 63.1 nM
Compound 4: middle estimate off by 1.6-fold (0.20 log units), on the high side; the range from low to high includes it.
By their numbers in this assay, from the lowest: compounds 4 and 3 (each within the scatter of the next); then compounds 1 and 2 (each within the scatter of the next).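

Exchanging 4-fluorophenyl for 2-bromophenyl on an oxygen on a saturated carbon gives, in this assay, a 1.9-fold lower number from compound 3 to compound 4 (0.28 log units; within the scatter). This shows that this position accepts either group with no difference that stands clear of the scatter, something compounds 1 and 2 could not show, as neither carries a group on this oxygen. Nothing available here measures any property of these groups that would explain this result.

The halogen and its place on the phenyl ring change together in this one step, so the compounds shown cannot tell the two changes apart. Also open, on these data alone, is how this position would respond to plain phenyl, to 2-fluorophenyl or 4-bromophenyl, which would separate those two changes, or to a phenyl ring carrying an amine or a nitrile.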